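The compounds below may be only part of what the source reports. "The series", "measured", "known", "first", "only" and "open" are said of these compounds alone.

Working notes on the series, a functional assay on Shh Light II cells (Mus musculus) for inhibition, read by a luciferase reporter; a higher number here means a weaker inhibitor, a lower number a stronger inhibitor.

Compound 1 `O=C(Nc1ccccc1Cl)N1CCN(c2nc(-c3ccc4ccccc4n3)no2)CC1` gives 140 nM in this assay; compound 3 `O=C(NC1CCCCC1)N1CCN(c2nc(-c3ccc4ccccc4n3)no2)CC1` gives 53 nM; compound 2 `Cc1ccccc1NC(=O)N1CCC(c2nc(-c3ccc4ccccc4n3)no2)CC1` gives 440 nM. Compound 2 therefore stands with the highest of the three numbers, with compound 1 nearest and compound 3 furthest below it, both gaps beyond the scatter. Among the measured compounds shown here, the one step measured within one change is a 2.6-fold lower number from compound 1 to compound 3 (0.42 log units; beyond the scatter), a modest move toward a lower number. Compounds 1 and 2 differ in more than one place, so their values are only shown side by side, not read as a step.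

Compound 4 `O=C(Nc1ncccc1Cl)N1CCC(c2nc(-c3ccc4ccccc4n3)no2)CC1` is not yet measured. It differs from compound 2 in one place, (3-chloropyridin-2-yl in place of 2-methylphenyl on an amide-type nitrogen). For the measured compounds named here, no measured step covers this exchange of one aromatic ring for another on the amide-type nitrogen; the only step in hand, from compound 1 to compound 3, concerns a different group and gives no direct guide. The two aryl ureas on file, compound 1 and compound 2, sit at the upper end of the range, which suggests compound 4 will remain in that region. A small step toward a lower number is expected for compound 4, a 1.5-fold lower number from compound 2 to compound 4 (0.17 log units; within the scatter), of a size near the scatter rather than clearly beyond it. The estimate for compound 4 is 300 nM, with a range from 110 nM to 850 nM.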

Compound 4, half-maximal inhibitory concentration: 2800 nM
For compound 4 the middle estimate is 9.3-fold (0.97 log units) below the measured one, and the stated range ends below it.
By their numbers in this assay, from the lowest: compound 3; then compound 1; then compound 2; then compound 4.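

In this assay, 3-chloropyridin-2-yl in place of 2-methylphenyl on an amide-type nitrogen gives a 6.4-fold higher number from compound 2 to compound 4 (0.80 log units; beyond the scatter), so this position responds clearly to an exchange between two aromatic groups with the same count of heavy atoms. Among the compounds shown here, the only earlier step at this kind of position, a 2.6-fold lower number from compound 1 to compound 3 (0.42 log units; beyond the scatter), replaced an aromatic group with cyclohexyl; the new step is the first between two aromatic groups and runs in the opposite direction, leaving compound 4 at 2800 nM, the highest number of the four. Nothing on hand gives a reason for the size of this step.

The exchange brings in a ring nitrogen and a chlorine and removes a methyl group in one move, so the compounds shown cannot divide the step among these parts; an unsubstituted pyridin-2-yl or a 3-methylpyridin-2-yl on the core of compound 2 would begin to separate them. Also open, from the compounds shown here alone, is whether the step from an aromatic group to cyclohexyl seen on the core of compound 1 carries over to the core of compound 2.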